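This account rests on a few compounds, and the source may have more. Where it says the series, first, only, none or still open, it means among the compounds named here.

Compound 3 `CO/N=c1\[nH]cnc2c1[n+](C/C=C(\C)CC/C=C(\C)CC/C=C(\C)CCC=C(C)C)cn2CCC#N` sits second highest among the three numbers in a functional assay on cells (Homo sapiens) for cytotoxicity; on this read-out higher numbers stand for weaker inhibition and lower numbers for stronger inhibition: compound 3 gives 3960 nM. The lowest number belongs to compound 2 `C=CCn1c[n+](C/C=C(\C)CC/C=C(\C)CC/C=C(\C)CCC=C(C)C)c2/c(=N/OC)[nH]cnc21`, which in this assay gives 1250 nM, and the highest to compound 1 `CC(C)=CCC/C(C)=C/CC/C(C)=C/CC/C(C)=C/C[n+]1cn(C)c2nc[nH]/c(=N\OCc3ccccc3)c21`, which in this assay gives 8240 nM. Within the data shown here, the only measured step between two compounds that differ in a single place, a 3.2-fold higher number from compound 2 to compound 3 (0.50 log units; beyond the scatter), alters a different part of the molecule from the one changed here.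

Compound 4 `CC(C)=CCC/C(C)=C/CC/C(C)=C/CC/C(C)=C/C[n+]1cn(CCC#N)c2nc[nH]/c(=N\OCc3ccccc3)c21` differs from compound 3 by phenyl in place of hydrogen on a saturated chain carbon bound to an oxygen. Among the measured compounds shown here, no measured step traces this exact change by itself. The nearest comparison is compound 1, which also carries the benzyloxy group but differs from compound 3 in a second place as well, so its higher number in this assay gives only a weak hint of direction, and the two differences in compound 1 cannot be separated. On that basis a modest shift upward is expected, a 1.8-fold higher number from compound 3 to compound 4 (0.25 log units; within the scatter), with wide uncertainty. Compound 4 is therefore estimated at 7000 nM in this assay, with a range from 3000 nM to 16000 nM.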

Compound 4, half-maximal inhibitory concentration: 9460 nM
Compound 4: middle estimate off by 1.4-fold (0.13 log units), on the low side; low and high end bracket the measured number.
By their numbers in this assay, from the lowest: compound 2; then compound 3; then compounds 1 and 4 (each within the scatter of the next).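

In this assay, among these compounds, replacing methoxy with benzyloxy, which puts phenyl in place of hydrogen on a saturated chain carbon bound to an oxygen, gives a 2.4-fold higher number from compound 3 to compound 4 (0.38 log units; beyond the scatter); this is the first direct reading of this change, and it points to weaker inhibition with the phenyl present. With the benzyloxy group held constant, the change at the other site gives a 1.1-fold higher number from compound 1 to compound 4 (0.06 log units; within the scatter), so that swap produces no shift that can be told from repeat-to-repeat noise in this setting. No supporting measurement is available to explain either result.

The compounds shown carry only methoxy and benzyloxy on this oxygen, so it remains open whether ethoxy, a longer chain such as phenethyloxy, or a free hydroxyl would give a number nearer compound 3 or compound 4. Going by these compounds, it also remains open whether the change at the aromatic nitrogen would have as little effect with methoxy on the oxygen instead of benzyloxy.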